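Swapping a Cyclobutyl for an Ethyl on a Weak Binder

The compounds below may be only part of what the source reports. "The series", "measured", "known", "first", "only" and "open" are said of these compounds alone.

Of the compounds shown here, three sharing one core have been tested in an assay on isolated protein for binding affinity to adenosine receptor A1 (Bos taurus); on this read-out higher numbers stand for weaker inhibition and lower numbers for stronger inhibition. Compound 1 `CCCCCCNc1nc(-c2ccccc2)nc2c1nnn2Cc1ccccc1` gives 13200000 nM, compound 2 `Clc1ccccc1Cn1nnc2c(NC3CCC3)nc(-c3ccccc3)nc21` gives 24000000 nM, and compound 3 `FC(F)(F)c1ccccc1Cn1nnc2c(NC3CCCC3)nc(-c3ccccc3)nc21` gives 600000 nM. Compound 2 and compound 1 sit together at the weak end, their numbers within the usual scatter of each other, while compound 3 lies far lower, beyond the scatter. Compound 4 `CCNc1nc(-c2ccccc2)nc2c1nnn2Cc1ccccc1Cl` differs from compound 2 in one place: ethyl in place of cyclobutyl on a nitrogen on an aromatic ring. Going by the values given here, no measured pair isolates this change, so the expectation rests on compound 2 alone. Compound 4 is expected to give 30000000 nM, with a range from 8000000 nM to 120000000 nM. The estimated step of a 1.3-fold higher number from compound 2 to compound 4 (0.10 log units; within the scatter) is expected to stay within the scatter.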

Compound 4, inhibition constant: 463000000 nM
For compound 4 the middle estimate is 15-fold (1.19 log units) below the measured one, and the stated range ends below it.
By their numbers in this assay, from the lowest: compound 3; then compounds 1 and 2 (each within the scatter of the next); then compound 4.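

Exchanging cyclobutyl for ethyl on this nitrogen produces a 19-fold higher number from compound 2 to compound 4 (1.29 log units; beyond the scatter) in this assay, so even a small change at this position can shift the read-out strongly. The change removes the four-membered ring and leaves a group with no ring, while neither group has a hydrogen-bond donor or acceptor. No independent evidence explains why the step is so large.

Still open, going by these compounds, is whether the ring or simply the size of the group matters. A cyclopropyl ring or a propyl chain on this nitrogen, with the rest of compound 2 unchanged, would help separate the two.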